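Replacing the aminophenyl at the carbonyl with a difluorophenyl

The source may hold more compounds than are shown below. What is called first, only, known or untested is meant among the compounds shown, and "the series" means these compounds.

Compound 1 `COc1cc(-c2cc(/C=C/C(=O)c3ccc(N)cc3)[nH]n2)cc(OC)c1OC` has been tested in a functional assay on SF-268 cells (Homo sapiens) for cytotoxicity, read by sulforhodamine B assay, with a stated time of 48 h, tested at 0.1 uM (a lower number here means a stronger effect, a higher number a weaker effect of the compound at the concentration tested), where compound 1 gives 106%, the highest of the three numbers recorded. Compound 2 `COc1ccc(-c2cc(/C=C/C(=O)c3ccc(N)cc3)[nH]n2)cc1OC` gives 101% in this assay, and the step of a number 5 percentage points lower from compound 1 to compound 2 (within the scatter) accompanies hydrogen in place of methoxy on an aromatic carbon. Compound 3 `COc1ccc(-c2cc(/C=C/C(=O)c3cc(OC)c(OC)c(OC)c3)[nH]n2)cc1OC` gives 93% in this assay, a number that lies beyond the scatter from compound 1; since compound 3 differs from compound 1 in more than one place, the two values can only be set side by side.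

Compound 4 `COc1cc(-c2cc(/C=C/C(=O)c3ccc(F)c(F)c3)[nH]n2)cc(OC)c1OC` has not yet been measured in this assay. It differs from compound 1 in one place: 3,4-difluorophenyl in place of 4-aminophenyl on a carbonyl carbon. Among the compounds with values here, none of the measured steps concerns the group on the carbonyl carbon; the single measured step of a number 5 percentage points lower from compound 1 to compound 2 (within the scatter) belongs to the other aromatic ring and stayed within the scatter. With all three known numbers sitting close together, there is no basis in the data for a step beyond the scatter. Compound 4 is therefore expected to give about 100% in this assay, with a range from 85% to 115%. The expected step of a number 6 percentage points lower from compound 1 to compound 4 (within the scatter) is estimated to stay within the scatter.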

Compound 4, a percentage reported as activity, at one concentration (the size of the read-out at that concentration, not a potency): 94%
Beside the measured number, compound 4's estimate is 6 percentage points above it; the range from low to high includes it.
By their numbers in this assay, from the lowest: compounds 3, 4, 2 and 1 (each within the scatter of the next, the first and the last beyond it).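

Within the data shown here, at the carbonyl carbon, 3,4-difluorophenyl in place of 4-aminophenyl gives the first single change in this assay that passes beyond the scatter, with a number 12 percentage points lower from compound 1 to compound 4 (beyond the scatter) as its step. The only earlier single change, on the methoxy-bearing aromatic ring, stayed within the scatter with a number 5 percentage points lower from compound 1 to compound 2 (within the scatter) as its step, so the group on the carbonyl carbon is the one place among these compounds where a single exchange has moved the read-out, though only modestly and at one concentration. Nothing available here accounts for this step, so the exchange can be recorded but not explained.

The change removes the amino group and brings in two fluorines at once, so a plain phenyl or a 4-fluorophenyl on the carbonyl carbon would be needed to separate the two parts, while a 4-hydroxyphenyl or a benzoic acid group there would show how far the read-out moves with other substituents. As far as these compounds go, it also remains open whether the same exchange would give a step of similar size on the core of compound 2, and whether the difference persists at other concentrations in this assay.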